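The source may report more compounds than this note shows. Statements on the series, on what has been measured and on what is new or still open speak of the compounds shown alone.

The study turns on three compounds measured in a functional assay on EKVX cells (Homo sapiens) for inhibition, read by sulforhodamine B assay, with a stated time of 48 h; on this read-out higher numbers stand for weaker inhibition of growth and lower numbers for stronger inhibition of growth. Compound 1 `CC1CCCc2c1nc(N)c(C#N)c2-c1cccn1C` sits at the limit of the assay, giving > 100000 nM. Compound 3 `COc1ccc(-c2cc(-c3cccn3C)c(C#N)c(N)n2)cc1OC` likewise reaches only the limit, at > 100000 nM. Compound 2 `Cn1cccc1-c1cc(-c2cccs2)nc(N)c1C#N`, the starting point of the step followed here, also yields no number but the limit, > 100000 nM. Where compound 2 stands is told only by the limit of > 100000 nM in this assay, at which 3 of the 3 values shown sit: none of the three compounds shows a measurable value, and nothing separates any of them from the others.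

The step leads to compound 4 `Cn1cccc1-c1cc(-c2ccccc2)nc(N)c1C#N`, which has not yet been measured. Its change from compound 2 is phenyl in place of thiophen-2-yl on an aromatic carbon. Among the compounds with values here, no measured pair differs in one place, so there is no step to lean on; with every value resting at the limit, no movement beyond the usual scatter is anticipated in this assay in either direction. Compound 4 is accordingly expected to show 150000 nM, within 50000 nM to 500000 nM, most likely reported once more as a limit. The implied change is expected to be a step that the limit leaves unreadable from compound 2 to compound 4.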

Compound 4, concentration for 50% growth inhibition: 95500 nM
Beside the measured number, compound 4's estimate is 1.6-fold (0.20 log units) above it; the range from low to high includes it.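

In this assay compound 4 gives 95500 nM, the only value among the compounds shown that is a number and not a limit, with phenyl on the aromatic carbon next to the ring nitrogen where compound 2 carries thiophen-2-yl. Phenyl in place of thiophen-2-yl gives an at least 1.0-fold lower number from compound 2 to compound 4 (0.01 log units; that floor lies within the scatter), so the data supply only a floor for this change, and that floor does not establish a real shift at this position. The true size of the step cannot be read because compound 2 is known only as a limit: the limit of > 100000 nM in this assay, at which 3 of the 4 values shown sit.

Going by these compounds, it remains open whether the number for compound 4 marks the start of a trend at this position or simply sits close to the edge of what this read-out can measure. On these data alone, it is also open whether a methoxyphenyl group, a pyridyl ring or an amine on the same carbon would give numbers clearly lower than that of compound 4 in this assay, and whether the other two groups on the core matter to that outcome.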